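From chloro to fluoro on a shared core

A few compounds are considered here, and "the series" means these few. Any claim that something is new, unique, unknown or untested is made for them only; others in the source may bear on it.

Within the data shown here, in a physicochemical assay for pharmacokinetics, at pH 8 (a higher number here means that the compound lasts longer, a lower number that the compound disappears faster), compound 1 `O=C(Sc1cccnc1C(=O)O)c1ccc(Cl)cc1` gives (26.6 h) and stands second highest of the three compounds measured so far. Compound 3 `COc1cccc(C(=O)Sc2cccnc2C(=O)O)c1` lies higher (63.7 h) and compound 2 `O=C(Sc1cccnc1C(=O)O)c1cccc(C(F)(F)F)c1` lies lower (10 h), both beyond the scatter from compound 1.

The next compound is compound 4 `O=C(Sc1cccnc1C(=O)O)c1ccc(F)cc1`, with fluoro in place of chloro on an aromatic carbon. Among the measured compounds shown here, no measured step makes this exchange. For the measured compounds named here, the only measured step that bears on it at all is a 6.4-fold higher number from compound 2 to compound 3 (0.80 log units; beyond the scatter) with methoxy in place of trifluoromethyl on an aromatic carbon. That modest step shows that one exchange on an aromatic carbon can move the number beyond the scatter, but it involves different groups and gives only a loose upper guide. A smaller step is therefore expected here, slightly upward and probably within the scatter. The estimated change is a 1.2-fold higher number from compound 1 to compound 4 (0.08 log units; within the scatter) and no more than that is expected. Compound 4 is expected at 32 h with an estimated range (16 h to 65 h).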

Compound 4, half-life: 111 h
Estimate against measurement, compound 4: 3.5-fold (0.54 log units) below; measured number above the stated range.
By their numbers in this assay, from the lowest: compound 2; then compound 1; then compounds 3 and 4 (each within the scatter of the next).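

Putting fluoro in place of chloro on an aromatic carbon, para to a large group, gives a 4.2-fold higher number from compound 1 to compound 4 (0.62 log units; beyond the scatter) in this assay. The earlier compounds shown here showed such a move only for methoxy in place of trifluoromethyl; this step shows that it also occurs when each group counts as 1 heavy atom and neither brings a ring, a hydrogen-bond donor or acceptor, or a net charge. Nothing available explains why the half-life responds so clearly to this exchange.

The compounds shown leave open how an amine or a methyl group would compare with fluoro and chloro at this same place. From the compounds shown here alone, this exchange also rests on a single pair, so whether it would repeat on another core remains unknown.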